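A few compounds are considered here, and "the series" means these few. Any claim that something is new, unique, unknown or untested is made for them only; others in the source may bear on it.

Measured compounds:
- compound 1, `CC1=NN(C(=O)c2ccc(C)cc2)C(c2cc(Br)cc(Br)c2O)C1`, 41200 nM
- compound 2, `CC1=NN(C(=O)CN2CCC(c3ccccc3)CC2)C(c2ccccc2O)C1`, 20400 nM
- compound 3, `O=C(CCl)N1N=C(c2cc3ccccc3oc2=O)CC1c1ccccc1`, 2980 nM

In a functional assay on PC-3 cells (Homo sapiens) for cytotoxicity, read by MTT assay, with a stated time of 48 h (a lower number here means a stronger inhibitor, a higher number a weaker inhibitor), compound 3 has the lowest number of the three. Compound 2 stands nearest to it, with a number that is beyond the scatter higher, and compound 1 stands furthest, also beyond the scatter. Compound 3 is therefore the strongest inhibitor of the set as measured.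

Compound 4, `CCCNCC(=O)N1N=C(c2cc3ccccc3oc2=O)CC1c1ccccc1`, has not yet been measured in this assay. It is derived from compound 3 by one change: propylamino in place of chloro on a saturated chain carbon bound to a carbonyl carbon. The shared core of compound 3 and compound 4 is kept, and the only part that moves is the group on the saturated chain carbon bound to the carbonyl carbon.

Within the data shown here, no pair of measured compounds that differ in one place is available, so the size of this step cannot be read from a precedent. The account expects a moderate step toward a higher number, since compound 2, which also carries an amino group on its acyl chain rather than a halogen, gives 20400 nM, though compound 2 and compound 3 differ in several places and so only their two values can be compared. The step from compound 3 to compound 4 is estimated as a 2.7-fold higher number from compound 3 to compound 4 (0.43 log units; beyond the scatter). Compound 4 is expected to give 8000 nM, within a range from 2500 nM to 25000 nM.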

Compound 4, half-maximal inhibitory concentration: 7270 nM
Estimate against measurement, compound 4: 1.1-fold (0.04 log units) above; measured number inside the range.
By their numbers in this assay, from the lowest: compound 3; then compound 4; then compound 2; then compound 1.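

In this assay, among these compounds, the replacement of chloro by propylamino on a saturated chain carbon bound to a carbonyl carbon gives the first step that can be read at this position: a 2.4-fold higher number from compound 3 to compound 4 (0.39 log units; beyond the scatter) with the shared core held fixed. The earlier compounds shown here offered no pair differing in one place, so they could not separate this group from the rest of the structure, whereas this step shows that chloro can give way to a larger group carrying an amine hydrogen at a modest cost, with compound 4 still at 7270 nM in this assay. Nothing available explains why the number rises.

Going by these compounds, with a single step at this position, it remains open whether the amine hydrogen of propylamino matters, which a tertiary amine such as piperidine or morpholine on the same chain carbon could test. On these data alone, it is also open how a longer chain on the amine, or bromo or fluoro in place of chloro, would compare with the two groups seen here.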